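The compounds below may be only part of what the source reports. "The series", "measured", "known", "first", "only" and "open" are said of these compounds alone.

Measured compounds:
compound 1 `CC(C)Cc1ccc(C(C)c2nnc3n2N=C(c2ccc(OC(F)(F)F)cc2)CS3)cc1`: 3600 nM
compound 2 `CC(c1ccc(-c2ccccc2)c(F)c1)c1n[nH]c(=S)n1N`: 43100 nM
compound 3 `COc1ccc2cc(C(C)c3n[nH]c(=S)n3N)ccc2c1`: 40800 nM

All three numbers come from a functional assay on Huh-7 cells (Homo sapiens) for inhibition, read by sulforhodamine B assay, with a stated time of 72 h; on this read-out lower numbers stand for stronger inhibition and higher numbers for weaker inhibition. Compound 1 stands lowest of the three; compound 3 is the nearest to it and compound 2 the furthest, and both gaps lie beyond the usual scatter. Among the compounds with values here, neither compound 2 nor compound 3 is connected to compound 1 by a change in a single place, so the record holds no step between measured compounds to draw on.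

Compound 4 `CC(C)Cc1ccc(C(C)c2nnc3n2N=C(c2ccc([N+](=O)[O-])cc2)CS3)cc1` has not been measured. It differs from compound 1 in one place: nitro in place of trifluoromethoxy on an aromatic carbon. The group sits para to a large group, and everything else in the molecule, including the shared core, is kept.

Within the data shown here, with no measured step to lean on, the expectation rests on the small size of the change alone. A step of no more than the usual scatter is expected in this assay, with no firm direction, so compound 4 should land close to compound 1. Compound 4 is expected to give about 3200 nM in this assay, within a range of 1100 nM to 9500 nM. The step this implies, from compound 1 to compound 4, is estimated at a 1.1-fold lower number from compound 1 to compound 4 (0.05 log units; within the scatter).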

Compound 4, half-maximal inhibitory concentration: "not active" (no number reported)
Compound 4: no number reported; no gap can be computed for the estimate.
By their numbers in this assay, from the lowest: compound 1; then compounds 3 and 2 (each within the scatter of the next).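

In this assay compound 4 is reported as not active, with no number; the step from compound 1 to compound 4 cannot be read. The compounds shown leave open how other groups on that aromatic carbon would read out on the shared core. No measured property bears on this result.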